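Capping the hydroxy group of compound 3 as methoxy

The compounds below may be only part of what the source reports. "The series", "measured", "known", "first", "only" and "open" are said of these compounds alone.

Of the compounds shown here, three have been measured in a functional assay on MCF7 cells (Homo sapiens) for antiproliferative activity, read by MTT assay, with a stated time of 48 h; on this read-out lower numbers stand for stronger inhibition and higher numbers for weaker inhibition. Compound 1 (`CC(=O)O[C@]1(C)/C=C/C(=O)/C(CO)=C\C[C@](C)(CCC=C(C)C)/C=C/[C@H]1OC(=O)C=C(C)C`) gives 2320 nM and compound 2 (`COCOC/C1=C/C[C@](C)(CCC=C(C)C)/C=C/[C@@H](OC(=O)C=C(C)C)[C@](C)(O)/C=C/C1=O`) gives 3120 nM, two values within the scatter of each other. Compound 3 (`CC(C)=CCC[C@]1(C)/C=C/[C@@H](OC(=O)C=C(C)C)[C@](C)(O)/C=C/[C@H](O)/C(CO)=C\C1`) gives 33000 nM, the highest number of the three and so the weakest inhibition, and it lies beyond the scatter from both of the others.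

Compound 4 (`CO[C@H]1/C=C/[C@@](C)(O)[C@H](OC(=O)C=C(C)C)/C=C/[C@@](C)(CCC=C(C)C)C/C=C\1CO`) is the next compound to be read against compound 3. The change is methyl in place of hydrogen on an oxygen on a saturated carbon, which turns a hydroxy into a methoxy. The rest of the structure stays the same.

Going by the values given here, the series offers no measured step between compounds that differ in one place, so this change has no direct precedent. The expectation therefore rests on compound 3 at 33000 nM as its starting point, and no step beyond the scatter is expected in this assay. The expected shift is a 1.3-fold lower number from compound 3 to compound 4 (0.12 log units; within the scatter), a small estimated move towards a lower number. For compound 4 the estimated value is 25000 nM, with an expected range of 8000 nM to 70000 nM.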

Compound 4, half-maximal inhibitory concentration: 18500 nM
Estimate against measurement, compound 4: 1.4-fold (0.13 log units) above; the range from low to high includes it.
By their numbers in this assay, from the lowest: compounds 1 and 2 (each within the scatter of the next); then compounds 4 and 3 (each within the scatter of the next).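

In this assay, going by these compounds alone, methyl in place of hydrogen on an oxygen on a saturated carbon gives a 1.8-fold lower number from compound 3 to compound 4 (0.25 log units; within the scatter), the first step between compounds that differ in one place. At this position, hydroxy to methoxy therefore leaves the read-out within the scatter, so the hydrogen on this oxygen is not needed to keep the value seen for compound 3. Nothing at hand explains this result or bears on the reason for it.

Still open, as far as these compounds go, is whether a benzyl group on this oxygen, or an amine in place of the hydroxy group, would also stay within the scatter of compound 3. Also open, from the compounds shown here alone, is whether methyl on either of the other hydroxy groups of compound 3 would give a step of similar size, so this single step cannot be extended to those positions.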